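Replacing the aryl group on the alkene of compound 1

The compounds below may be only part of what the source reports. "The series", "measured", "known", "first", "only" and "open" are said of these compounds alone.

Compound 1 `O=C(/C(=C\c1ccc(O)c([N+](=O)[O-])c1)SCc1ccc(Cl)cc1)c1ccc(Cl)cc1`: 10000 nM
Compound 2 `O=C(/C(=C\c1ccc(O)c([N+](=O)[O-])c1)SCc1ccccc1Cl)c1ccc(Cl)cc1`: 10000 nM

In a functional assay on DU-145 cells (Homo sapiens) for inhibition, read by trypan blue exclusion, with a stated time of 96 h (on this read-out lower numbers stand for stronger inhibition of growth and higher numbers for weaker inhibition of growth), compound 1 gives 10000 nM and stands level with compound 2, which gives 10000 nM. Among the compounds with values here, the single measured step, no change at the digits printed from compound 1 to compound 2 (within the scatter), alters the group on the sulfur-bound chain carbon and stays within the scatter. Compound 3 `Cc1ccc(C)c(/C=C(/SCc2ccc(Cl)cc2)C(=O)c2ccc(Cl)cc2)c1` differs from compound 1 elsewhere: 2,5-dimethylphenyl in place of 4-hydroxy-3-nitrophenyl on a double-bonded chain carbon bound to a double-bonded chain carbon. Within the data shown here, no measured step touches that position, so nothing in the data points to a shift in either direction, and the expectation for compound 3 rests on the level of compound 1. Compound 3 is therefore expected to give 10000 nM, estimated between 3000 nM and 30000 nM, an expected step of no change at the digits printed from compound 1 to compound 3 (within the scatter).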

Compound 3, concentration for 50% growth inhibition: 10000 nM
For compound 3 middle estimate and measured number coincide at the digits printed; the range from low to high includes it.
By their numbers in this assay, from the lowest: compounds 1, 2 and 3 (each within the scatter of the next).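

In this assay, 2,5-dimethylphenyl in place of 4-hydroxy-3-nitrophenyl on a double-bonded chain carbon bound to a double-bonded chain carbon gives no change at the digits printed from compound 1 to compound 3 (within the scatter). Within the data shown here, this is the first reading at this position, and it shows that an aryl group with 0 hydrogen-bond donors and 0 hydrogen-bond acceptors reads level with one carrying 1 hydrogen-bond donor and 3 hydrogen-bond acceptors. Nothing available offers an explanation for this result. The compounds shown leave open whether an amine or a carboxylic acid on the aryl group at this position would move the number.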